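The compounds below may be only part of what the source reports. "The series", "measured", "known", "first", "only" and "open" are said of these compounds alone.

Measured compounds:
compound 1, `COC(=O)C(C(=O)c1ccc(Cn2ccc3ccc(NC(=O)CC4CCCC4)cc32)c(OC)c1)S(=O)(=O)c1ccccc1`, 10.1
compound 2, `COc1cc(C(=O)NS(=O)(=O)c2cccs2)ccc1Cn1ccc2ccc(NC(=O)CC3CCCC3)cc21`, 9.6

Of the compounds shown here, two sharing one core have been measured in a functional assay (trachea) for antagonist activity, with Cavia porcellus as the target; a lower number here means a less potent compound, a higher number a more potent compound, by a factor of ten per unit of this negative logarithm. In this assay compound 1 gives 10.1, and compound 2 gives 9.6. Of the two numbers, compound 2 stands at the lower one, and the gap to compound 1 lies beyond the scatter; the two differ in more than one place, so nothing further is read from that pair.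

The step followed here leads from compound 2 to compound 3, `COc1cc(C(=O)NS(=O)(=O)c2c(C)cccc2Cl)ccc1Cn1ccc2ccc(NC(=O)CC3CCCC3)cc21`, which is not yet measured in this assay. For the measured compounds named here, the single change is 2-chloro-6-methylphenyl in place of thiophen-2-yl on a sulfonyl sulfur. Going by the values given here, no measured pair shows the effect of such a change, so the expectation rests on compound 2 alone. A step of no more than the usual scatter, in either direction, is expected, given as a number 0.10 log units higher from compound 2 to compound 3 (within the scatter). For compound 3 the estimate in this assay is 9.7, with a range from 9.2 to 10.2.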

Compound 3, negative logarithm of the antagonist equilibrium constant: 8.8
The estimate for compound 3 lay 0.90 log units above the measured number; the measured number lies below the stated range.
By their numbers in this assay, from the lowest: compound 3; then compound 2; then compound 1.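

For the compounds shown here, the sulfonyl sulfur, whose other neighbour is the amide-type nitrogen, proves to be a place where the choice of group matters: in this assay, 2-chloro-6-methylphenyl in place of thiophen-2-yl gives a number 0.80 log units lower from compound 2 to compound 3 (beyond the scatter) and so supplies the first single-place comparison in this small set. The earlier pair differed in more than one place and could say nothing of this kind, whereas this step shows that, for these two groups, exchanging a five-membered aromatic ring with one hetero atom for a six-membered aromatic ring of carbon only, carrying chlorine and methyl, lowers the potency number. No measurement at hand bears on why the number falls.

A single step cannot separate the change of ring from the contribution of the chlorine or the methyl, and a plain phenyl, a 2-chlorophenyl or a 2-methylphenyl on the sulfonyl sulfur would be needed to tell these apart. From the compounds shown here alone, whether a simple alkyl group such as methyl at this sulfur would hold the number of compound 2 also remains open.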